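Sulfonamide hydrazides: notes on an unmeasured fluorobenzoyl analogue

The compounds below may be only part of what the source reports. "The series", "measured", "known", "first", "only" and "open" are said of these compounds alone.

Measured so far:
compound 1 `Cc1cccc(NNC(=O)c2ccc(NS(=O)(=O)c3cnc(O)nc3O)cc2)c1`, > 20000 nM
compound 2 `O=C(NNc1cccc(Cl)c1)c1cccc(NS(=O)(=O)c2cnc(O)nc2O)c1`, 8040 nM
compound 3 `O=C(NNc1ccccc1Cl)c1ccccc1NS(=O)(=O)c1cnc(O)nc1O`, 14100 nM

In a functional assay on OVCAR-3 cells (Homo sapiens) for antiproliferative activity, read by MTT assay, with a stated time of 24 h (on this read-out higher numbers stand for weaker inhibition and lower numbers for stronger inhibition), compound 1 gives > 20000 nM, which is a limit of the assay and not a number. Compound 1 stands at the limit of > 20000 nM in this assay, at which 1 of the 3 values shown sits. Among the compounds with values here, compound 2 and compound 3 are the two members with a numerical value in this assay; no step between them and compound 1 is described, so they serve only as the range of numbers seen so far.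

Compound 4 `O=C(NNC(=O)c1ccc(NS(=O)(=O)c2cnc(O)nc2O)cc1)c1ccc(F)cc1` is not yet measured. It differs from compound 1 by (4-fluorophenyl)carbonyl in place of 3-methylphenyl on an amine nitrogen.

With compound 1 known only as a limit, the step is expected to be modest and of uncertain direction; compound 4 is estimated at 15000 nM, within 4000 nM to 40000 nM, an expected step of an at least 1.3-fold lower number from compound 1 to compound 4 (0.12 log units; that floor lies within the scatter).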

Compound 4, half-maximal inhibitory concentration: > 20000 nM
Compound 4 was reported as a limit; the forecaster's own chance of this, stated with the estimate: 40%; middle value at least 1.3-fold (0.12 log units) away from the limit.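

In this assay compound 4 gives > 20000 nM, a limit of the assay and not a number. Compound 1 also stands at a limit, so no step between compound 1 and compound 4 can be read: the limit of > 20000 nM in this assay, at which 2 of the 4 values shown sit.

As far as these compounds go, whether (4-fluorophenyl)carbonyl in place of 3-methylphenyl shifts the value at all stays open.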